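From trifluoromethyl to chloro on an aromatic carbon

The source may report more compounds than this note shows. Statements on the series, on what has been measured and on what is new or still open speak of the compounds shown alone.

Compound 1 `COc1cc(OC)c(OC)cc1/C=C/COC(=O)/C=C/c1c(OC)ccc(OC)c1OC`: <= 80 mg/kg (a limit)
Compound 2 `COc1cc(OC)c(OC)cc1/C=C/COC(=O)/C=C/c1ccc(Br)cc1`: 105 mg/kg
Compound 3 `COc1cc(OC)c(OC)cc1/C=C/COC(=O)/C=C/c1ccccc1C(F)(F)F`: 123 mg/kg

In a functional assay on the whole organism (strain Kunming) with Mus musculus as the target, in the formalin test, with a stated time of 0.5 h (on this read-out higher numbers stand for an effect only at larger amounts of compound and lower numbers for an effect already at smaller amounts), compound 3 gives 123 mg/kg. Among the measured compounds shown here, only one measured step bears on its standing, a 1.2-fold higher number from compound 2 to compound 3 (0.07 log units; within the scatter), so these two numbers cannot be told apart. Compound 1 has only a limit, not a number. Compound 4 `COc1cc(OC)c(OC)cc1/C=C/COC(=O)/C=C/c1ccccc1Cl` differs from compound 3 as follows: chloro in place of trifluoromethyl on an aromatic carbon. For the measured compounds named here, the one measured exchange of groups, a 1.2-fold higher number from compound 2 to compound 3 (0.07 log units; within the scatter), stayed small, so no step beyond the scatter is expected in this assay, in either direction. The expected change is a 1.1-fold lower number from compound 3 to compound 4 (0.05 log units; within the scatter). The estimate for compound 4 is 110 mg/kg, with an expected range from 65 mg/kg to 185 mg/kg.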

Compound 4, dose for half-maximal effect: 101 mg/kg
Compound 4: the middle estimate sits 1.1-fold (0.04 log units) above what was measured; the measured number falls inside the stated range.
By their numbers in this assay, from the lowest: compounds 4, 2 and 3 (each within the scatter of the next). At a limit, below all of these: compound 1.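

At this aromatic carbon, ortho to a large group, a single chlorine atom can replace the four heavy atoms of trifluoromethyl and the number in this assay stays within the scatter: a 1.2-fold lower number from compound 3 to compound 4 (0.09 log units; within the scatter). Swapping the whole 4-bromophenyl for 2-chlorophenyl gives the same picture: a 1.0-fold lower number from compound 2 to compound 4 (0.02 log units; within the scatter). Compound 2, compound 3 and compound 4 therefore cannot be told apart, while compound 1 has only a limit, not a number: the limit of <= 80 mg/kg in this assay, at which 1 of the 4 values shown sits.

From the compounds shown here alone, whether an amine or a carboxylic acid on this aromatic carbon would move the number beyond the scatter remains open.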